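Dihalophenyl swap on an aminoquinoline-type anilide series

This account rests on a few compounds, and the source may have more. Where it says the series, first, only, none or still open, it means among the compounds named here.

Compound 1 `CC(C)c1ccc(Nc2ccc3c(OCCCN4CCN(C)CC4)cccc3n2)cc1` gives 11000 nM in a functional assay on NCI-H322M cells (Homo sapiens) for inhibition, read by sulforhodamine B assay, with a stated time of 48 h; a lower number here means a stronger inhibitor of growth, a higher number a weaker inhibitor of growth.
Compound 2 `CN1CCN(CCCOc2cccc3nc(Nc4ccc(F)c(F)c4)ccc23)CC1` gives 3930 nM in this assay.

Among the compounds with values here, compound 2 stands lowest of the two numbers so far; its nearest neighbour is compound 1, and the step of a 2.8-fold lower number from compound 1 to compound 2 (0.45 log units; beyond the scatter) is beyond the scatter, so compound 2 is the stronger of the pair. Compound 3 `CN1CCN(CCCOc2cccc3nc(Nc4cc(Cl)cc(Cl)c4)ccc23)CC1` has not yet been measured. It differs from compound 2 by 3,5-dichlorophenyl in place of 3,4-difluorophenyl on a nitrogen on an aromatic ring. Within the data shown here, the only measured step, the one from compound 1 to compound 2, concerns a different exchange on the same nitrogen, from a 4-isopropylphenyl to a 3,4-difluorophenyl, and was modest in size. Among the measured compounds shown here, no measured step compares one dihalophenyl with another, so there is nothing to show whether moving from two fluorines to two chlorines, with the changed 3,5-pattern, shifts the number at all. Compound 3 is therefore expected to stay close to compound 2, with the estimated step of a 1.1-fold lower number from compound 2 to compound 3 (0.05 log units; within the scatter) not beyond the scatter in either direction. Compound 3 is expected to give about 3500 nM in this assay, within a range from 1200 nM to 10000 nM.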

Compound 3, concentration for 50% growth inhibition: 1560 nM
The estimate for compound 3 lay 2.2-fold (0.35 log units) above the measured number; measured number inside the range.
By their numbers in this assay, from the lowest: compound 3; then compound 2; then compound 1.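

In this assay, the exchange of one dihalophenyl for another on this nitrogen does shift the number: the change is a 2.5-fold lower number from compound 2 to compound 3 (0.40 log units; beyond the scatter), even though the leaving and entering groups have the same computed heavy-atom count and neither carries a hydrogen-bond donor or acceptor. Replacing 4-isopropylphenyl with 3,5-dichlorophenyl gives a 7.1-fold lower number from compound 1 to compound 3 (0.85 log units; beyond the scatter), and since compound 3 has steps to both of the others printed as beyond the scatter, it is the strongest inhibitor of growth among the three compounds shown. Nothing available explains why the 3,5-dichlorophenyl group gives the lower number.

The step from compound 2 to compound 3 changes both the halogen and its pattern on the ring, so the compounds shown cannot separate the two changes; a 3,4-dichlorophenyl or a 3,5-difluorophenyl group on the same nitrogen would be needed to do so. They also leave open whether the trend continues to other groups in this place, such as 3,5-dibromophenyl or 3,5-bis(trifluoromethyl)phenyl.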